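Two Weak Amides and a Thiazolyl Sulfone Analogue

A few compounds are considered here, and "the series" means these few. Any claim that something is new, unique, unknown or untested is made for them only; others in the source may bear on it.

Measured so far in a functional assay (Cavia porcellus) with sulfonylurea receptors; K-ATP channels (Homo sapiens) as the target; a lower number here means a stronger inhibitor, a higher number a weaker inhibitor:
compound 1, `COc1ccc(S(=O)(=O)c2ccc(NC(=O)C(C)(O)C(F)(F)F)cc2)cc1`, gives > 30000 nM, which is a limit of the assay and not a number.
compound 2, `CC(O)(C(=O)Nc1ccc(C(O)c2ccccc2)cc1)C(F)(F)F`, gives > 30000 nM, likewise only a limit.

The two measured compounds share the same hydroxy amide core bearing a trifluoromethyl group and differ only in the group attached to the far side of the anilide. Compound 2 stands at the weak end of everything shown: the limit of > 30000 nM in this assay, at which 2 of the 2 values shown sit. No number is available for it, and nothing separates it from compound 1.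

Compound 3, `CC(O)(C(=O)Nc1ccc(S(=O)(=O)c2nccs2)cc1)C(F)(F)F`, differs from compound 2 in one place: (1,3-thiazol-2-yl)sulfonyl in place of hydroxy(phenyl)methyl on an aromatic carbon. Going by the values given here, no step between two numbered values exists in this set, so the size of such a change cannot be read from any measured pair. Compound 1 likewise carries a sulfonyl-linked aromatic group and likewise sits only at the limit. The expectation for compound 3 is therefore no step beyond the scatter, a step that the limit leaves unreadable from compound 2 to compound 3, with a further limit the most likely outcome. Compound 3 is estimated at 40000 nM, between 10000 nM and 150000 nM.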

Compound 3, half-maximal inhibitory concentration: 1400 nM
For compound 3 the middle estimate is 29-fold (1.46 log units) above the measured one; measured number below the stated range.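

In this assay, the group on this aromatic carbon, para to a large group, can clearly move the result: (1,3-thiazol-2-yl)sulfonyl in place of hydroxy(phenyl)methyl gives an at least 21-fold lower number from compound 2 to compound 3 (1.33 log units; beyond the scatter) and so brings the first real number into the set. A sulfonyl link alone does not account for this, since compound 1 has one too, and 1,3-thiazol-2-yl in place of 4-methoxyphenyl on the sulfonyl sulfur gives an at least 21-fold lower number from compound 1 to compound 3 (1.33 log units; beyond the scatter) and so shows that the group carried by the sulfonyl matters. Going by these compounds alone, both steps start from a limit of the assay and not from a number, so their true sizes stay unknown, and compound 3 is the only compound that leaves that limit: the limit of > 30000 nM in this assay, at which 2 of the 3 values shown sit.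

The step from compound 2 swaps the link and the ring together, so a hydroxy(1,3-thiazol-2-yl)methyl group would be needed to show which of the two counts. As far as these compounds go, whether the thiazole ring itself is required also stays open, and a pyridin-2-yl group on the sulfonyl sulfur would test that.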